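The source may hold more compounds than are shown below. What is called first, only, known or untested is meant among the compounds shown, and "the series" means these compounds.

Compound 3, with the structure `Nc1nc(-c2ccco2)nc2sc(-c3ccccc3)nc12`, is the point of departure. In a functional assay on CHO cells for antagonist activity at adenosine receptor A2b (Homo sapiens), read by cAMP accumulation, with a stated time of 10 min (a higher number here means a weaker inhibitor, a lower number a stronger inhibitor), compound 3 gives > 30000 nM, which is a limit of the assay and not a number. Compound 1, of structure `Nc1nc(-c2ccc(CO)cc2)nc2sc(-c3ccccc3)nc12`, differs from it in the group on the aromatic carbon, and in this assay compound 1 gives > 30000 nM, again a limit. Compound 2, of structure `N#Cc1cccc(-c2nc(N)c3nc(-c4ccccc4)sc3n2)c1`, gives > 30000 nM in this assay, also a limit. Because (the limit of > 30000 nM in this assay, at which 3 of the 3 values shown sit), the steps a step that the two limits leave unreadable from compound 1 to compound 2, a step that the two limits leave unreadable from compound 1 to compound 3 and a step that the two limits leave unreadable from compound 2 to compound 3 cannot be read in size, so compound 3 stands at the limit alongside the others. Compound 4 has the structure `Cc1ccc(-c2nc(N)c3nc(-c4ccccc4)sc3n2)o1` and differs from compound 3 by methyl in place of hydrogen on an aromatic carbon, that is furan-2-yl to 5-methylfuran-2-yl. Among the compounds with values here, none of the measured steps reports a readable size, so no direction is expected beyond the scatter. For compound 4 in this assay the value is estimated at 40000 nM, within 8000 nM to 200000 nM, which means an expected step that the limit leaves unreadable from compound 3 to compound 4.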

Compound 4, half-maximal inhibitory concentration: > 30000 nM
Compound 4: only a limit was reported (the forecaster's own chance of this, stated with the estimate: 75%); the middle value lies beyond the limit too.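

In this assay compound 4 gives > 30000 nM, a limit and not a number. Within the data shown here, no step linking compound 1, compound 2, compound 3 and compound 4 can be read in size, because all of them share this ceiling: the limit of > 30000 nM in this assay, at which 4 of the 4 values shown sit. The compounds shown leave open whether any of these groups on the aromatic carbon, methyl included, changes inhibition at all.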